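A few compounds are considered here, and "the series" means these few. Any claim that something is new, unique, unknown or untested is made for them only; others in the source may bear on it.

Series notes: in a functional assay on K562 cells (Homo sapiens) for cytotoxicity, read by MTT assay, with a stated time of 24 h (on this read-out higher numbers stand for weaker inhibition and lower numbers for stronger inhibition), compound 1 (`COc1cc(/C=C2\CN(C)C/C(=C\c3ccccc3F)C2=O)cc(OC)c1`) gives 6320 nM, compound 2 (`COc1cc(/C=C2\CN(C)C/C(=C\c3ccc(F)cc3)C2=O)cc(OC)c1`) gives 11300 nM and compound 3 (`COc1cc(/C=C2\CN(C)C/C(=C\c3ccc(Cl)c(Cl)c3)C2=O)cc(OC)c1`) gives 9490 nM. Compound 3 stands within the scatter of both other compounds, so no order is drawn among the three.

Compound 4 (`COc1cc(/C=C2\CN(C)C/C(=C\c3ccc(C#N)cc3)C2=O)cc(OC)c1`) follows from compound 3 by one change: 4-cyanophenyl in place of 3,4-dichlorophenyl on a double-bonded chain carbon bound to a double-bonded ring carbon. This places 4-cyanophenyl in place of 3,4-dichlorophenyl on a double-bonded chain carbon bound to a double-bonded ring carbon.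

Going by the values given here, three measured steps bear on this place: a 1.8-fold higher number from compound 1 to compound 2 (0.25 log units; within the scatter), a 1.5-fold higher number from compound 1 to compound 3 (0.18 log units; within the scatter) and a 1.2-fold lower number from compound 2 to compound 3 (0.08 log units; within the scatter). All three lie within the scatter, so these three compounds show no sensitivity to the group exchanged there. Among the compounds with values here, none of them carries 4-cyanophenyl, and the data give no direct precedent for it. No step beyond the scatter is therefore expected in this assay, and no direction is favoured.

The estimated step is a 1.1-fold lower number from compound 3 to compound 4 (0.02 log units; within the scatter).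

For compound 4 the expected value is 9000 nM, with an estimated range from 4000 nM to 20000 nM.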

Compound 4, half-maximal inhibitory concentration: 4650 nM
Compound 4: the middle estimate sits 1.9-fold (0.29 log units) above what was measured; the range from low to high includes it.
By their numbers in this assay, from the lowest: compounds 4, 1, 3 and 2 (each within the scatter of the next, the first and the last beyond it).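

In this assay, going by these compounds alone, this place proves sensitive to the exchange after all: the move to 4-cyanophenyl gives a 2.0-fold lower number from compound 3 to compound 4 (0.31 log units; beyond the scatter) and a 2.4-fold lower number from compound 2 to compound 4 (0.39 log units; beyond the scatter) as the first steps here beyond the scatter, both modest. The sensitivity is limited, since the change from 2-fluorophenyl gives a 1.4-fold lower number from compound 1 to compound 4 (0.13 log units; within the scatter) and leaves compound 4 and compound 1 unordered, so the nitrile is set apart only from 3,4-dichlorophenyl and 4-fluorophenyl. No measurement shown explains this difference.

As far as these compounds go, whether the gain belongs to the nitrile itself remains open, and a carboxylic acid or an amine on the same phenyl ring would test how far it extends. Also open, from the compounds shown here alone, is whether the steps would persist with a group other than 3,5-dimethoxyphenyl on the other side of the shared core.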